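Swapping chloro for nitro on compound 3

The source may report more compounds than this note shows. Statements on the series, on what has been measured and on what is new or still open speak of the compounds shown alone.

In a functional assay on HO8910 cells (Homo sapiens) for inhibition, read by MTT assay, with a stated time of 24 h, tested at 100 ug/mL (a lower number here means less inhibition of growth, a higher number more inhibition of growth at the concentration tested), three compounds have been measured so far. Compound 1 `O=C(CCCCC1CCSS1)NO` is reported as "not active" (no number reported), without a number. Compound 2 `O=C(CCCCC1CCSS1)Nc1cccc(C(F)(F)F)c1` reaches 74.8%. Compound 3 `O=C(CCCCC(S)CCS)Nc1ccc(Cl)cc1` gives 21.3%, the lower of the two numbers and beyond the scatter from compound 2. Compound 4 `O=C(CCCCC(S)CCS)Nc1ccc([N+](=O)[O-])cc1` has nitro in place of chloro on an aromatic carbon of compound 3, para to a large group (nitro in place of chloro on an aromatic carbon). Among the measured compounds shown here, no measured pair differs in one place only, so the data offer no direct guide to this change. A small upward move that stays within the scatter is expected, with an estimated a number 6.7 percentage points higher from compound 3 to compound 4 (within the scatter). Compound 4 is expected at 28%, with an estimated range of 8% to 55%.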

Compound 4, percent growth inhibition at one concentration: 51.2%
The estimate for compound 4 lay 23.2 percentage points below the measured number; measured number inside the range.
By their numbers in this assay, from the lowest: compound 3; then compound 4; then compound 2.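

At this aromatic carbon, para to a large group, nitro in place of chloro gives a number 29.9 percentage points higher from compound 3 to compound 4 (beyond the scatter) in this assay. Among the compounds shown here, this is the first comparison here that changes one place only, and it shows that the group at this carbon can alter growth inhibition. Nothing measured here explains the difference. On these data alone, whether an amine, a nitrile or a methoxy group at this carbon would give a similar step remains open. So does whether the same swap would have a similar effect on the core of compound 2.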